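The source may hold more compounds than are shown below. What is called first, only, known or untested is meant among the compounds shown, and "the series" means these compounds.

Working notes on the series

Three compounds of a shared core have been looked at in an in vitro ADME assay on microsomes from liver (Homo sapiens) for metabolic stability; on this read-out higher numbers stand for fast clearance and lower numbers for slow clearance. Compound 1 `COc1ccccc1C1CCc2nc[nH]c2C1` carries a methoxy on its pendant ring, but in this assay compound 1 gives "not determined" (no result reported), so no result is available for it. Compound 2 `COc1ccc(C2CCc3nc[nH]c3C2)cc1` gives 16 mL.min-1.g-1 in this assay. Compound 3 `COc1ccc(C2Cc3nccn3C2)cc1`, with a smaller core, gives 30 mL.min-1.g-1 in this assay.

Among the two numbers available, compound 2 stands at the lower end, with compound 3 its nearest neighbour; the gap between the two lies within the usual scatter of repeated measurements, so the two values cannot be ordered with confidence. Compound 1 adds no number.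

Compound 4 `c1ccc(C2CCc3nc[nH]c3C2)cc1` is the next entry and differs from compound 2 in a single place: hydrogen in place of methoxy on an aromatic carbon. Among the measured compounds shown here, no pair of measured compounds isolates this change, so there is no measured step to lean on for size or direction. For the measured compounds named here, the only anchor is the value of compound 2 in this assay.

With that as the sole basis, no step beyond the scatter is expected from compound 2 to compound 4, in either direction. Compound 4 is therefore estimated at 14 mL.min-1.g-1 in this assay, within a range of 6 mL.min-1.g-1 to 32 mL.min-1.g-1, which corresponds to an expected step of a 1.1-fold lower number from compound 2 to compound 4 (0.06 log units; within the scatter).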

Compound 4, intrinsic clearance in microsomes: 7 mL.min-1.g-1
For compound 4 the middle estimate is 2.0-fold (0.30 log units) above the measured one; the measured number falls inside the stated range.
By their numbers in this assay, from the lowest: compound 4; then compounds 2 and 3 (each within the scatter of the next).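

Among the compounds shown here, the replacement of hydrogen for methoxy on the aromatic carbon, para to a group of 9 heavy atoms, gives in this assay the first readable single-change step: a 2.3-fold lower number from compound 2 to compound 4 (0.36 log units; beyond the scatter). This shows that the position is not silent in this assay, and that methoxy at this carbon is not needed for a low clearance number on the shared core, since the step beyond the scatter runs towards slower clearance on its removal, though it is modest and rests on this one pair. Nothing available bears on what lies behind the step, so the observation stands as an empirical one.

From the compounds shown here alone, it remains open whether other groups on the same aromatic carbon, such as fluorine, chlorine, hydroxyl, ethoxy or trifluoromethyl, would give numbers near that of compound 4 or nearer that of compound 2, which would show whether methoxy is a special case or one of many groups that behave alike. Also open, going by these compounds, is whether hydrogen in place of methoxy gives a step of similar size and the same direction on the smaller core of compound 3.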